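Removing the Phenoxycarbonyl Cap from the Aromatic Nitrogen

This account rests on a few compounds, and the source may have more. Where it says the series, first, only, none or still open, it means among the compounds named here.

Compound 1 `COc1ccc(S(=O)(=O)N2CCc3cccc(NC(=O)c4ccc(C#N)cc4)c32)cc1`: 105 nM
Compound 2 `COc1ccc(S(=O)(=O)N2CCc3cccc(NS(=O)(=O)c4ccc(F)cc4)c32)cc1`: 1200 nM
Compound 3 `COc1ccc(S(=O)(=O)N2CCc3cccc(NC(=O)Oc4ccccc4)c32)cc1`: > 10000 nM (a limit of the assay, not a number)

In a functional assay on KB cells (Homo sapiens) for cytotoxicity (on this read-out higher numbers stand for weaker inhibition and lower numbers for stronger inhibition), compound 1 gives 105 nM and compound 2 gives 1200 nM. For compound 3 only a limit is known, > 10000 nM, so compound 3 stands at the weak end of the three. The steps of an at least 95-fold higher number from compound 1 to compound 3 (1.97 log units; beyond the scatter) and an at least 8.3-fold higher number from compound 2 to compound 3 (0.92 log units; beyond the scatter) both show large losses on arriving at the phenoxycarbonyl group. Compound 4 `COc1ccc(S(=O)(=O)N2CCc3cccc(N)c32)cc1` differs from compound 3 by hydrogen in place of phenoxycarbonyl on a nitrogen on an aromatic ring. No measured step removes this group entirely, so those steps bear on the change only indirectly and give no reason to expect a recovery. Compound 4 is therefore expected to remain weak, estimated at 15000 nM (range 3000 nM to 60000 nM), a step that the limit leaves unreadable from compound 3 to compound 4 that is expected to lie within the scatter.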

Compound 4, half-maximal inhibitory concentration: 2800 nM
Estimate against measurement, compound 4: 5.4-fold (0.73 log units) above; measured number below the stated range.
By their numbers in this assay, from the lowest: compound 1; then compound 2; then compound 4. At a limit, above all of these: compound 3.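

Swapping the phenoxycarbonyl group for hydrogen gives a real gain (an at least 3.5-fold lower number from compound 3 to compound 4 (0.55 log units; beyond the scatter)), so this cap does worse at the nitrogen than having no cap at all. The other two caps do better than hydrogen (a 2.3-fold higher number from compound 2 to compound 4 (0.37 log units; beyond the scatter) and a 27-fold higher number from compound 1 to compound 4 (1.43 log units; beyond the scatter)), so groups at this nitrogen can either raise or lower the activity of the free amine. The first of these steps is only a minimum, as compound 3 is known only as a limit of the assay: the limit of > 10000 nM in this assay, at which 1 of the 4 values shown sits.

Going by these compounds, it remains open whether a small acetyl or methyl group on this nitrogen would beat hydrogen. An unsubstituted benzoyl group would also be needed to separate the contribution of the nitrile in compound 1 from that of its amide.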